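Oximes at the benzylic oxygen of a shared quinolinylmethoxy core

The source may report more compounds than this note shows. Statements on the series, on what has been measured and on what is new or still open speak of the compounds shown alone.

Measured compounds:
compound 1, `O=C(O)CSC(CCCc1ccc(Cl)cc1)c1ccc(OCc2ccc3ccccc3n2)cc1`, 7 nM
compound 2, `O=C(O)[C@@H](c1ccc(OCc2ccc3ccccc3n2)cc1)C1CCCC1`, 60 nM
compound 3, `O=C(O)/C(CSCCO)=N/OC(c1ccc(OCc2ccc3ccccc3n2)cc1)C1CCCCC1`, 181 nM

All three were tested in a functional assay for inhibition of Polyunsaturated fatty acid 5-lipoxygenase (Homo sapiens); on this read-out lower numbers stand for stronger inhibition and higher numbers for weaker inhibition. Compound 3 stands at the highest number of the three; compound 2 sits at a lower number, beyond the scatter, and compound 1 lies furthest away, also beyond the scatter. Compound 4, `O=C(O)c1ccc(/C=N/OC(c2ccc(OCc3ccc4ccccc4n3)cc2)C2CCCCC2)cc1`, has not been measured in this assay. It differs from compound 3 in one place: a group of 11 heavy atoms (8 carbon, 1 nitrogen, 2 oxygen; one six-membered aromatic ring of carbon only) in place of a group of 10 heavy atoms (5 carbon, 1 nitrogen, 3 oxygen, 1 sulfur; no ring), on an oxygen on a saturated carbon. For the measured compounds named here, no step between two measured compounds resembles this change, so the data give no direct guide to its size. Given that the rest of the molecule is unchanged, the step from compound 3 to compound 4 is expected to be small, a 1.2-fold lower number from compound 3 to compound 4 (0.08 log units; within the scatter), with no clear direction beyond the scatter. For compound 4 the estimated value in this assay is 150 nM, with a plausible range from 40 nM to 600 nM.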

Compound 4, half-maximal inhibitory concentration: 31 nM
For compound 4 the middle estimate is 4.8-fold (0.68 log units) above the measured one, outside the stated range (below it).
By their numbers in this assay, from the lowest: compound 1; then compounds 4 and 2 (each within the scatter of the next); then compound 3.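

In this assay, putting the group with one six-membered aromatic ring of carbon only in place of the sulfur-containing group without a ring, on an oxygen on a saturated carbon, gives a 5.8-fold lower number from compound 3 to compound 4 (0.77 log units; beyond the scatter). For the compounds shown here, this is the first one-place comparison in the set, and it shows that the number at this position responds to the group placed there, with the ring-bearing group giving the stronger inhibition of the two. Nothing at hand explains why the number moves in this direction.

The two compounds cannot separate the contribution of the aromatic ring from that of the carboxylic acid within the entering group. Going by these compounds, how an unsubstituted phenyl group, a methyl ester or a longer chain ending in a carboxylic acid would read at this position remains open.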